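A few compounds are considered here, and "the series" means these few. Any claim that something is new, unique, unknown or untested is made for them only; others in the source may bear on it.

Measured so far:
Compound 1, `O=[N+]([O-])c1ccc(-c2ccc3c(O)cccc3c2)cc1`: in an assay for binding affinity to 17-beta-hydroxysteroid dehydrogenase type 2 (Homo sapiens), with a stated time of 20 min, tested at 1 uM (on this read-out lower numbers stand for less inhibition and higher numbers for more inhibition at the one concentration tested (going by the name of the read-out)), compound 1 gives 13%
Compound 2, `CS(=O)(=O)Nc1cccc(-c2ccc3c(O)cccc3c2)c1`: in this assay compound 2 gives 22%

Compound 1 stands at the lower of the two numbers, but the gap to compound 2 lies within the usual scatter of such measurements, so no real difference between the two has been established. Both values are small, meaning that neither compound blocks much of the enzyme at the concentration tested.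

Compound 3, `CNC(=O)c1ccc(-c2ccc3c(O)cccc3c2)cc1`, has not been measured. It shares its core with compound 1 and differs from it in one place: methylcarbamoyl in place of nitro on an aromatic carbon. Within the data shown here, no pair of measured compounds differing in a single place is available, so the size of this step cannot be read from the data. Without such a guide, the step from compound 1 to compound 3 is expected to be small and is estimated as a number 2 percentage points higher from compound 1 to compound 3 (within the scatter), no larger than the scatter. Compound 3 is therefore estimated to give 15%, within a range of 3% to 30%.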

Compound 3, a percentage reported as inhibition, at one concentration (the size of the read-out at that concentration, not a potency): 13%
Compound 3: the middle estimate sits 2 percentage points above what was measured; measured number inside the range.
By their numbers in this assay, from the lowest: compounds 1, 3 and 2 (each within the scatter of the next).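

Among these compounds, the pair of compound 1 and compound 3 is the first in which a single change can be read: in this assay, placing methylcarbamoyl instead of nitro on this aromatic carbon, para to a large group, gives no change at the digits printed from compound 1 to compound 3 (within the scatter). The two groups differ in their heavy atoms and in their hydrogen-bond donors and acceptors, yet this read-out does not separate them at this position. No separate measurement bears on this result.

On these data alone, whether any other group at this position would move the read-out beyond the scatter stays open, for instance an amine, a carboxylic acid or a longer chain on the amide nitrogen. Among the compounds shown here, compound 2 differs from compound 1 and compound 3 in more than one place, so no step to it can be read.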